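The compounds below may be only part of what the source reports. "The series", "measured", "known", "first", "only" and "open" are said of these compounds alone.

Compound 1, `COc1ccc(N/C=C\C(=O)c2nc(-c3ccc(C(F)(F)F)cc3)n3ccccc23)cc1OC`, was tested in a functional assay on BT-474 cells (Homo sapiens) for cytotoxicity, read by MTT assay, with a stated time of 48 h; a higher number here means a weaker inhibitor, a lower number a stronger inhibitor. In that assay compound 1 gives > 30000 nM, which is a limit of the assay rather than a measured number, so compound 1 stands at the edge of what this assay can report, as shown by the limit of > 30000 nM in this assay, at which 1 of the 2 values shown sits. A second compound, compound 2, `O=C(/C=C\Nc1cnc2ccccc2c1)c1nc(-c2ccccc2)n2ccccc12`, differs from compound 1 in more than one place, so no single step can be read between the two; in this assay compound 2 gives 19700 nM, a weak result as well. Compound 3, `O=C(/C=C\Nc1ccc(F)cc1)c1nc(-c2ccc(C(F)(F)F)cc2)n2ccccc12`, has not been measured. It differs from compound 1 by 4-fluorophenyl in place of 3,4-dimethoxyphenyl on an amine nitrogen. Among the compounds with values here, no measured pair covers this change, so there is no direct guide to its effect. The expected step of an at least 1.0-fold lower number from compound 1 to compound 3 (0.02 log units; that floor lies within the scatter) is none beyond the scatter. Compound 3 is estimated at 28000 nM, with a range from 10000 nM to 60000 nM, and a fair chance that this assay again returns only a limit.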

Compound 3, half-maximal inhibitory concentration: > 30000 nM
Compound 3 was reported as a limit; the forecaster's own chance of this, stated with the estimate: 50%; middle value at least 1.0-fold (0.02 log units) away from the limit.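

In this assay, within the data shown here, compound 3 gives > 30000 nM, which is a limit and not a number, as it is for compound 1, so no step between compound 1 and compound 3 can be read. The compounds shown leave open whether 4-fluorophenyl in place of 3,4-dimethoxyphenyl on an amine nitrogen changes the result at all.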